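A few compounds are considered here, and "the series" means these few. Any claim that something is new, unique, unknown or untested is made for them only; others in the source may bear on it.

Of the compounds shown here, two have numbers so far in a functional assay on CCRF-CEM cells (Homo sapiens) for antiproliferative activity (a higher number here means a weaker inhibitor of growth, a lower number a stronger inhibitor of growth), and they sit close together. Compound 1 (`CC/C=C\[C@H](C)[C@H](OC(N)=O)[C@@H](C)[C@H](O)[C@@H](C)C/C(C)=C\[C@H](C)[C@@H](O)[C@@H](C)/C=C\[C@@H](O)C[C@@H]1OC(=O)[C@H](C)C[C@H]1C`) gives 8.6 nM and compound 2 (`CC/C=C\[C@H](C)[C@H](OC(N)=O)[C@@H](C)[C@H](O)[C@@H](C)C/C(C)=C\[C@H](C)[C@@H](O)[C@@H](C)/C=C\[C@@H](O)C[C@H]1CCC(=O)O1`) gives 6.5 nM with the pair inside the usual scatter, so compound 2 stands level with compound 1.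

Compound 3 (`CC/C=C\[C@H](C)[C@H](OC(N)=O)[C@@H](C)[C@H](O)[C@@H](C)C/C(C)=C\[C@H](C)[C@@H](O)[C@@H](C)/C=C\[C@@H](O)C[C@@H]1OC(=O)[C@H](C)[C@@H](OC)[C@H]1C`) keeps the long chain of compound 2 and differs only at one end, where the change is a group of 11 heavy atoms (8 carbon, 3 oxygen; one six-membered non-aromatic ring with 1 hetero atom) in place of a group of 6 heavy atoms (4 carbon, 2 oxygen; one five-membered non-aromatic ring with 1 hetero atom), on a saturated chain carbon, two bonds along the chain from a double-bonded chain carbon and an oxygen on a saturated carbon on a saturated chain carbon, two bonds along the chain from a double-bonded chain carbon and an oxygen on a saturated carbon.

One measured step falls at this same place. That step is a 1.3-fold lower number from compound 1 to compound 2 (0.12 log units; within the scatter) and it exchanged a six-membered ring group for a five-membered one without a shift beyond the scatter. For the measured compounds named here, compound 3 also has a six-membered ring, but its group is larger than the one in compound 1, and no measured compound tests that extra size. Going by the values given here, no step clearly beyond the scatter is therefore expected, with a small rise in the number the likelier direction. The estimated move is a 1.8-fold higher number from compound 2 to compound 3 (0.27 log units; within the scatter) on this reasoning. For compound 3 the expected value is 12 nM with an estimated range from 4 nM to 40 nM in repeat measurements.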

Compound 3, concentration for 50% growth inhibition: 4.4 nM
The estimate for compound 3 lay 2.7-fold (0.44 log units) above the measured number; the measured number falls inside the stated range.
By their numbers in this assay, from the lowest: compounds 3, 2 and 1 (each within the scatter of the next).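

In this assay, the largest group so far at this place, on a saturated chain carbon, still gives a result level with the much smaller group of compound 2: a 1.5-fold lower number from compound 2 to compound 3 (0.17 log units; within the scatter). The new information is the methoxy in place of hydrogen on a saturated ring carbon, which the earlier pair did not test: the step is a 2.0-fold lower number from compound 1 to compound 3 (0.29 log units; within the scatter), so this addition brings no shift that can be told apart from repeat scatter. All three compounds now stand level with one another, despite differences in ring size and in group size at this end of the molecule, and no supporting measurement is available to explain this tolerance.

All three groups shown keep a non-aromatic ring with 1 hetero atom at this place, so the effect of an open chain ending in a carboxylic acid, or of an amine in place of the methoxy, remains unknown. For the compounds shown here, with every step so far inside the scatter, it also remains open how far this end can be altered before the number moves clearly in either direction.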